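From a dichlorophenoxy ether to a fluorophenyl thioether

The compounds below may be only part of what the source reports. "The series", "measured", "known", "first", "only" and "open" are said of these compounds alone.

Compound 1 `Nc1cc(N)c2nc(-c3ccccc3)c(Oc3ccc(Cl)c(Cl)c3)nc2c1` was tested in a functional assay on HCT-116 cells (Homo sapiens) for inhibition, read by sulforhodamine B assay, with a stated time of 48 h (on this read-out lower numbers stand for stronger inhibition of growth and higher numbers for weaker inhibition of growth), and gave 47900 nM, the only plain number shown in this series. For compound 2 `CCOC(=O)[C@H](CCC(=O)O)NC(=O)c1ccc(Sc2nc3cc(N)cc(N)c3nc2-c2ccccc2)cc1` the result in this assay is only a limit of the assay, < 100000 nM, recorded as the limit of < 100000 nM in this assay, at which 1 of the 2 values shown sits. Compound 3 `Nc1cc(N)c2nc(-c3ccccc3)c(Sc3ccc(F)cc3)nc2c1` carries (4-fluorophenyl)sulfanyl in place of 3,4-dichlorophenoxy on an aromatic carbon. Going by the values given here, no measured pair shows a change of this kind, so the direction is open. For compound 3 the expected step is a 1.4-fold lower number from compound 1 to compound 3 (0.14 log units; within the scatter), no larger than the usual scatter. For compound 3 a value of 35000 nM is estimated, lying between 9000 nM and 100000 nM.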

Compound 3, concentration for total growth inhibition: 28200 nM
Beside the measured number, compound 3's estimate is 1.2-fold (0.09 log units) above it, within the range that was stated.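

Going by these compounds alone, the exchange of 3,4-dichlorophenoxy for (4-fluorophenyl)sulfanyl on this aromatic carbon next to the ring nitrogen gives a 1.7-fold lower number from compound 1 to compound 3 (0.23 log units; within the scatter) in this assay and is the first measured step at this position. In this read-out the two groups cannot be told apart, even though the linking atom and the ring halogens change together. Nothing measured here bears on the cause of this step. As far as these compounds go, whether the linking atom or the halogens matter separately stays open. So does whether an amine or carboxylic acid on this phenyl ring, or a longer chain at this carbon, would give a step beyond the scatter.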